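The source may hold more compounds than are shown below. What is called first, only, known or untested is meant among the compounds shown, and "the series" means these compounds.

Working notes on the series. Compound 1 `Fc1ccc(Oc2ncnc3[nH]ccc23)c(F)c1` and compound 2 `Cc1ccc(Oc2ncnc3[nH]ccc23)c(C)c1` share one core, while compound 3 `COc1ccc2c(Oc3ccc(F)cc3F)ncnc2c1` is built on a different core carrying a methoxy group. In an assay on HEK293-TREx cells for antagonist activity at transient receptor potential cation channel subfamily A member 1 (Homo sapiens), read by fluorescence and calcium flux, with a stated time of 72 h (on this read-out lower numbers stand for stronger inhibition and higher numbers for weaker inhibition), compound 1 gives 710 nM. For compound 2 this assay returns > 32000 nM, which is a limit of the assay and not a number, this being (the limit of > 32000 nM in this assay, at which 1 of the 3 values shown sits). Compound 3 gives 3000 nM in this assay, the higher of the two numbers obtained, and its gap to compound 1 lies beyond the scatter; the two structures differ in more than one place, so no single step can be read from that gap. Compound 4 `Fc1ccc(Oc2ncnc3ccccc23)c(F)c1` has not yet been measured. It differs from compound 3 by hydrogen in place of methoxy on an aromatic carbon. Within the data shown here, no pair of measured compounds differs in one place only, so there is no measured step to lean on for the loss of the methoxy group, and the direction of the change is open. The step is expected to stay small, a 1.2-fold lower number from compound 3 to compound 4 (0.08 log units; within the scatter). The estimate for compound 4 in this assay is 2500 nM, within a range from 600 nM to 10000 nM.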

Compound 4, half-maximal inhibitory concentration: > 32000 nM
Compound 4: only a limit was reported; the forecaster's own chance of this, stated with the estimate: 10%; at least 12-fold (1.10 log units) between middle value and limit.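

Among these compounds, the methoxy group on this aromatic carbon of the fused system matters in this assay: replacing it with hydrogen gives an at least 10-fold higher number from compound 3 to compound 4 (1.02 log units; beyond the scatter), the first step that can be read at a single place, and it is large where the earlier compounds offered no such comparison. Compound 4 gives > 32000 nM, which is a limit of the assay and not a number. The step is therefore a lower bound on the loss of the methoxy group, and its full size cannot be read, with a further compound now at the limit: the limit of > 32000 nM in this assay, at which 2 of the 4 values shown sit.

The compounds shown leave open whether methoxy itself is needed at this aromatic carbon, or whether a hydroxyl group, an ethoxy group, an amine or a fluorine atom there would hold the inhibition seen for compound 3. They also leave open whether methoxy would produce a step of similar size on the core of compound 1, or at the other aromatic carbons of the same ring.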